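The source may hold more compounds than are shown below. What is called first, only, known or untested is meant among the compounds shown, and "the series" means these compounds.

Of the compounds shown here, three built on one shared core have been measured in a functional assay on A549 cells (Homo sapiens) for inhibition, read by MTT assay, with a stated time of 72 h; on this read-out higher numbers stand for weaker inhibition and lower numbers for stronger inhibition. Compound 1 `COc1cc2c(Oc3ccc(NC(=O)c4nn(-c5ccccc5C(F)(F)F)c(=O)cc4C)cc3F)ccnc2cc1OCCCN1CCCCC1` gives 140 nM. Compound 2 `COc1cc2c(Oc3ccc(NC(=O)c4nn(-c5ccccc5OC(F)(F)F)c(=O)cc4C)cc3F)ccnc2cc1OCCCN1CCCCC1` gives 120 nM. Compound 3 `COc1cc2c(Oc3ccc(NC(=O)c4nn(-c5cccc(F)c5)c(=O)cc4C)cc3F)ccnc2cc1OCCCN1CCCCC1` gives 250 nM, the highest of the three numbers, although its gap to compound 1 stays within the scatter while its gap to compound 2 lies beyond it. The measured steps all concern the aryl group carried on the ring nitrogen of the core: a 1.2-fold lower number from compound 1 to compound 2 (0.07 log units; within the scatter); a 1.8-fold higher number from compound 1 to compound 3 (0.25 log units; within the scatter); a 2.1-fold higher number from compound 2 to compound 3 (0.32 log units; beyond the scatter).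

Compound 4 `COc1cc2c(Oc3ccc(NC(=O)c4nn(-c5ccc(Cl)cc5Cl)c(=O)cc4C)cc3F)ccnc2cc1OCCCN1CCCCC1` has not yet been measured. It differs from compound 3 in one place: 2,4-dichlorophenyl in place of 3-fluorophenyl on an aromatic nitrogen. The step from compound 3 to compound 4 again exchanges that aryl group. The steps of a 1.8-fold higher number from compound 1 to compound 3 (0.25 log units; within the scatter) and a 2.1-fold higher number from compound 2 to compound 3 (0.32 log units; beyond the scatter) bear on it most directly; both put the 3-fluorophenyl compound at the higher number, one within the scatter and one modestly beyond it. Since compound 3 gives 250 nM and the two compounds with a differently substituted phenyl give lower numbers, a modest move toward a lower number in this assay is expected for compound 4, by a 1.7-fold lower number from compound 3 to compound 4 (0.22 log units; within the scatter). Compound 4 is therefore estimated at 150 nM, with a range from 60 nM to 400 nM.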

Compound 4, half-maximal inhibitory concentration: 220 nM
Beside the measured number, compound 4's estimate is 1.5-fold (0.17 log units) below it, and the stated range covers the measured number.
By their numbers in this assay, from the lowest: compounds 2, 1, 4 and 3 (each within the scatter of the next, the first and the last beyond it).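

In this assay, for the compounds shown here, the 2,4-dichlorophenyl group of compound 4 is the first aryl group here to carry chlorine and more than one substituent, yet the exchange gives a 1.1-fold lower number from compound 3 to compound 4 (0.06 log units; within the scatter). Against the other two aryl groups it gives a 1.8-fold higher number from compound 2 to compound 4 (0.26 log units; within the scatter) and a 1.6-fold higher number from compound 1 to compound 4 (0.20 log units; within the scatter), so on this aromatic nitrogen the new group cannot be told apart from any of the three earlier ones, even though those earlier groups themselves include a pair that stands apart, with a 2.1-fold higher number from compound 2 to compound 3 (0.32 log units; beyond the scatter). Nothing shown here gives a measured reason for this closeness.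

Going by these compounds, it remains open whether the position accepts groups of a different kind just as well, such as a phenyl carrying an amine or a carboxylic acid, or a longer alkyl chain in place of the aryl group on that nitrogen. On these data alone, it is also open whether compound 4 would stay this close to the other compounds on a different cell line.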